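Loss of tert-butoxycarbonyl in a cytotoxicity series

A few compounds are considered here, and "the series" means these few. Any claim that something is new, unique, unknown or untested is made for them only; others in the source may bear on it.

Compound 1 `CC(C)(C)OC(=O)N[C@@H](CSC(Cl)=C(Cl)Cl)C(=O)N[C@@H]1[C@@H](O)[C@H](O)[C@@H](CO)O[C@H]1SC1CCCCC1`: 33000 nM
Compound 2 `N[C@@H](CSC(Cl)=C(Cl)Cl)C(=O)N[C@@H]1[C@@H](O)[C@H](O)[C@@H](CO)O[C@H]1SC1CCCCC1`: 121000 nM
Compound 3 `CC(C)(C)OC(=O)N[C@@H](CSC(Cl)=C(Cl)Cl)C(=O)N[C@@H]1[C@@H](O)[C@H](O)[C@@H](CO)O[C@@H]1SC1CCCCC1`: 103000 nM

In a functional assay on 1A9 cells (Homo sapiens) for cytotoxicity, read by MTT assay, with a stated time of 48 h (on this read-out higher numbers stand for weaker inhibition and lower numbers for stronger inhibition), compound 3 stands second highest of the three numbers; its nearest neighbour is compound 2, within the scatter, while compound 1 lies furthest, as the step of a 3.1-fold higher number from compound 1 to compound 3 (0.49 log units; beyond the scatter) shows, a step whose only structural basis is the fact that compounds 1 and 3 differ only in the configuration as drawn. Compound 4 `N[C@@H](CSC(Cl)=C(Cl)Cl)C(=O)N[C@@H]1[C@@H](O)[C@H](O)[C@@H](CO)O[C@@H]1SC1CCCCC1` differs from compound 3 as follows: hydrogen in place of tert-butoxycarbonyl on an amine nitrogen. The same change has been measured once, as a 3.7-fold higher number from compound 1 to compound 2 (0.56 log units; beyond the scatter), a modest weakening beyond the scatter. A step of similar size and direction is therefore expected here, a 3.4-fold higher number from compound 3 to compound 4 (0.53 log units; beyond the scatter). Compound 4 is thus estimated at 350000 nM, with a range from 150000 nM to 800000 nM.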

Compound 4, half-maximal inhibitory concentration: 79000 nM
For compound 4 the middle estimate is 4.4-fold (0.65 log units) above the measured one; the whole stated range lies above it.
By their numbers in this assay, from the lowest: compound 1; then compounds 4, 3 and 2 (each within the scatter of the next).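

Hydrogen in place of tert-butoxycarbonyl on the amine nitrogen gives (a 1.3-fold lower number from compound 3 to compound 4 (0.12 log units; within the scatter)), so the change does not carry over between the two configurations at the saturated ring carbon: the same change on two cores in this assay, a 3.7-fold higher number (0.56 log units; beyond the scatter) from compound 1 to compound 2 and a 1.3-fold lower number (0.12 log units; within the scatter) from compound 3 to compound 4, 4.8-fold (0.68 log units) apart, beyond the scatter of two such steps. With the free amino group, the configuration at that carbon leaves the two numbers within the scatter (a 1.5-fold lower number from compound 2 to compound 4 (0.19 log units; within the scatter)), unlike the step with tert-butoxycarbonyl in place (a 3.1-fold higher number from compound 1 to compound 3 (0.49 log units; beyond the scatter)). The compounds shown leave open how either configuration would respond to an acetyl or benzyloxycarbonyl group on that nitrogen.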